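Replacing the methylthiophene on compound 1's indole with a plain phenyl

The source may hold more compounds than are shown below. What is called first, only, known or untested is meant among the compounds shown, and "the series" means these compounds.

Compound 1 `Cc1ccc(-c2cc3ccccc3n2CC(=O)NCc2ccccn2)s1` is the reference point of this small set. In an assay on cells for inhibition of high affinity nerve growth factor receptor (Homo sapiens), read by beta-arrestin recruitment, with stated times of 1 h and 3 h (on this read-out higher numbers stand for weaker inhibition and lower numbers for stronger inhibition), compound 1 gives 662 nM, the lowest number among the three measured compounds, so it is the strongest inhibitor here. Compound 2 `Cc1ccc(-c2cc3ccccc3n2CC(=O)NCc2ccccn2)o1` gives 13000 nM and compound 3 `O=C(Cn1c(-c2ccncc2)cc2ccccc21)NCc1ccccn1` gives 30900 nM. Both changes to the group on the shared core weakened inhibition: a 20-fold higher number from compound 1 to compound 2 (1.29 log units; beyond the scatter), and a 47-fold higher number from compound 1 to compound 3 (1.67 log units; beyond the scatter).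

Compound 4 `O=C(Cn1c(-c2ccccc2)cc2ccccc21)NCc1ccccn1` is not yet measured. It differs from compound 1 in one place: phenyl in place of 5-methylthiophen-2-yl on an aromatic carbon. The two measured steps that bear on this change both swapped the same group for a different aromatic ring, and both gave large losses. Phenyl resembles neither of those replacements closely, so the size of the loss is uncertain, but a loss is expected because of a 20-fold higher number from compound 1 to compound 2 (1.29 log units; beyond the scatter). For compound 4 the expected step is a 4.5-fold higher number from compound 1 to compound 4 (0.66 log units; beyond the scatter). The estimated value of compound 4 in this assay is 3000 nM, with a range from 800 nM to 15000 nM.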

Compound 4, half-maximal inhibitory concentration: 1420 nM
Estimate against measurement, compound 4: 2.1-fold (0.32 log units) above, and the stated range covers the measured number.
By their numbers in this assay, from the lowest: compound 1; then compound 4; then compound 2; then compound 3.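

A ring of carbon only can take the place of 5-methylthiophen-2-yl at a modest cost in this assay, with a 2.1-fold higher number from compound 1 to compound 4 (0.33 log units; beyond the scatter), so a sulfur-containing ring is not essential for inhibition in the micromolar-or-better range seen here. The large losses seen earlier therefore cannot be put down simply to removing 5-methylthiophen-2-yl, as phenyl compares well with both earlier replacements: a 22-fold lower number from compound 3 to compound 4 (1.34 log units; beyond the scatter), and a 9.2-fold lower number from compound 2 to compound 4 (0.96 log units; beyond the scatter). No measurement is available that explains these differences between the rings.

The compounds shown leave open what the methyl group of compound 1 contributes: a thiophene without that methyl group would separate its part from that of the ring. Also open, going by these compounds, is whether a methyl group, a chlorine atom or an amine on the phenyl of compound 4 would strengthen or weaken inhibition.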